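The source may report more compounds than this note shows. Statements on the series, on what has been measured and on what is new or still open speak of the compounds shown alone.

Measured so far:
- compound 1 `COc1ccc(-c2cn3ccnc3c(-c3ccc4ncn(C5CCCCC5)c4c3)n2)cc1`: 95.2%
- compound 2 `Brc1ccc(-c2cn3ccnc3c(-c3ccc4ncn(C5CCCCC5)c4c3)n2)cc1`: 42.4%
- compound 3 `COc1ccccc1-c1cn2ccnc2c(-c2ccc3ncn(C4CCCCC4)c3c2)n1`: 43.1%

In a functional assay on PC-3 cells (Homo sapiens) for inhibition, read by sulforhodamine B assay, with a stated time of 48 h, tested at 10 uM (on this read-out lower numbers stand for less inhibition and higher numbers for more inhibition at the one concentration tested (going by the name of the read-out)), compound 3 is the second highest of the three numbers; its nearest neighbour is compound 2, the gap being a number 0.7 percentage points higher from compound 2 to compound 3 (within the scatter), while compound 1 lies far above it, as a number 52.1 percentage points lower from compound 1 to compound 3 (beyond the scatter) shows. Compound 4 `FC(F)(F)c1cccc(-c2cn3ccnc3c(-c3ccc4ncn(C5CCCCC5)c4c3)n2)c1` is not yet measured. It differs from compound 3 in one place: 3-(trifluoromethyl)phenyl in place of 2-methoxyphenyl on an aromatic carbon. Going by the values given here, two measured steps bear on swapping the group at this position. Going from the 4-methoxyphenyl of compound 1 to the 4-bromophenyl of compound 2 gave a number 52.8 percentage points lower from compound 1 to compound 2 (beyond the scatter), and to the 2-methoxyphenyl of compound 3 gave a number 52.1 percentage points lower from compound 1 to compound 3 (beyond the scatter), whereas between those two replacements the gap was only a number 0.7 percentage points higher from compound 2 to compound 3 (within the scatter). Among the compounds with values here, no step involves 3-(trifluoromethyl)phenyl, so the expected step from compound 3 is small, a number 1.9 percentage points higher from compound 3 to compound 4 (within the scatter), but the estimate is uncertain. Compound 4 is estimated at 45%, in the range 20% to 80%.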

Compound 4, a percentage reported as inhibition, at one concentration (the size of the read-out at that concentration, not a potency): 36.5%
For compound 4 the middle estimate is 8.5 percentage points above the measured one; the measured number falls inside the stated range.
By their numbers in this assay, from the lowest: compounds 4, 2 and 3 (each within the scatter of the next); then compound 1.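

In this assay a third replacement for the 4-methoxyphenyl group behaves like the first two: 3-(trifluoromethyl)phenyl gives a number 58.7 percentage points lower from compound 1 to compound 4 (beyond the scatter) and is a large step. The other two steps, a number 6.6 percentage points lower from compound 3 to compound 4 (within the scatter) and a number 5.9 percentage points lower from compound 2 to compound 4 (within the scatter), stay within the scatter, so three differently substituted phenyl groups cannot be told apart here and only compound 1 stands clear of them. Nothing measured on these compounds explains why.

Still open, as far as these compounds go, is whether the methoxy itself or its place on the ring matters, which 3-methoxyphenyl would help to separate. From the compounds shown here alone, whether 4-ethoxyphenyl or 4-aminophenyl keeps the high number of compound 1 is also open.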